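Replacing Bromo with Nitro: Expecting Compound 3

This account rests on a few compounds, and the source may have more. Where it says the series, first, only, none or still open, it means among the compounds named here.

Measured so far:
compound 1 `Nc1nc(N2CCCC2)sc1C(=O)/C=C/c1ccc(Cl)cc1` — 27 ug/mL
compound 2 `Nc1nc(N2CCCC2)sc1C(=O)/C=C/c1ccc(Br)cc1` — 30 ug/mL

Both compounds were tested in a functional assay on HepG2 cells (Homo sapiens) for antiproliferative activity, read by MTT assay, with a stated time of 48 h; a higher number here means a weaker inhibitor, a lower number a stronger inhibitor. Compound 1 gives 27 ug/mL, and compound 2 gives 30 ug/mL. The step of a 1.1-fold higher number from compound 1 to compound 2 (0.05 log units; within the scatter) is small. Compound 2 holds the highest of the two numbers, yet its nearest neighbour, compound 1, sits within the scatter, so the two cannot be ranked.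

Compound 3 `Nc1nc(N2CCCC2)sc1C(=O)/C=C/c1ccc([N+](=O)[O-])cc1` differs from compound 2 by nitro in place of bromo on an aromatic carbon. Within the data shown here, the only measured step, a 1.1-fold higher number from compound 1 to compound 2 (0.05 log units; within the scatter), concerns the exchange of one halogen for another and says nothing about a nitro group; no measured pair bears directly on this change. No step beyond the scatter in this assay is therefore expected in either direction, and the range is kept wide. Compound 3 is expected to give 30 ug/mL, between 12 ug/mL and 75 ug/mL. The expected step is no change at the digits printed from compound 2 to compound 3 (within the scatter).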

Compound 3, half-maximal inhibitory concentration: 23.5 ug/mL
Estimate against measurement, compound 3: 1.3-fold (0.11 log units) above, within the range that was stated.
By their numbers in this assay, from the lowest: compounds 3, 1 and 2 (each within the scatter of the next).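

In this assay, the earlier pair compared only one halogen with another, whereas nitro brings a different kind of group to this place on the six-membered aromatic ring, with a 1.3-fold lower number from compound 2 to compound 3 (0.11 log units; within the scatter) and a 1.1-fold lower number from compound 1 to compound 3 (0.06 log units; within the scatter) as the result. Nitro has three heavy atoms where bromo has one, and two hydrogen-bond acceptors where bromo has none, yet neither step rises above the scatter, so this place accepts the change without a readable shift in the number. Nothing available bears on the cause of this result.

Among these compounds, the three compounds show only that these particular groups cannot be told apart, so they set no general rule for this place. An amine, a carboxylic acid, a methoxy group or a plain hydrogen there remains an open question.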